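Removing one methoxy group from compound 2

This account rests on a few compounds, and the source may have more. Where it says the series, first, only, none or still open, it means among the compounds named here.

Measured compounds:
- Compound 1 `CC1(/C=C/c2ccccc2)C=CC(=O)O1`: 170000 nM
- Compound 2 `COc1ccc(/C=C/C2(C)C=CC(=O)O2)c(OC)c1`: 108000 nM
- Compound 3 `COc1ccc(/C=C/C2(C)C=CC(=O)O2)c(OC)c1OC`: 132000 nM

In a functional assay on 786-0 cells (Homo sapiens) for inhibition, read by sulforhodamine B assay, with a stated time of 48 h (a higher number here means a weaker inhibitor of growth, a lower number a stronger inhibitor of growth), compound 2 gives 108000 nM. That number lies within the usual scatter of those for compound 1 and compound 3, so the three cannot be put in any order.

The next compound to be tested is compound 4 `COc1ccccc1/C=C/C1(C)C=CC(=O)O1`. It differs from compound 2 by one change: hydrogen in place of methoxy on an aromatic carbon.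

Among the compounds with values here, one measured step bears directly on this, a methoxy swap in the opposite sense, a 1.2-fold higher number from compound 2 to compound 3 (0.09 log units; within the scatter). It is small. Compound 1, which has no methoxy group, gives 170000 nM, and this too stays within the scatter of compound 2. No step beyond the scatter is therefore expected, and no direction can be favoured in this assay.

The estimated step is a 1.2-fold higher number from compound 2 to compound 4 (0.08 log units; within the scatter), which is expected to remain within the scatter. For compound 4 the expected value is 130000 nM, with an estimated range from 80000 nM to 210000 nM.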

Compound 4, concentration for total growth inhibition: 35400 nM
Compound 4: middle estimate off by 3.7-fold (0.56 log units), on the high side; the measured number lies below the stated range.
By their numbers in this assay, from the lowest: compound 4; then compounds 2, 3 and 1 (each within the scatter of the next).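

In this assay, the methoxy group meta to a methoxy group and para to a group of 9 heavy atoms turns out to matter: taking it away gives a 3.1-fold lower number from compound 2 to compound 4 (0.48 log units; beyond the scatter). A single methoxy group on the otherwise bare aromatic ring also counts, giving a 4.8-fold lower number from compound 1 to compound 4 (0.68 log units; beyond the scatter), so a methoxy group does not shift the number by a fixed amount. What one more methoxy group does depends on the rest of the molecule: the same change on two cores in this assay, a 1.2-fold higher number (0.09 log units; within the scatter) from compound 2 to compound 3 and a 4.8-fold lower number (0.68 log units; beyond the scatter) from compound 1 to compound 4, 5.9-fold (0.77 log units) apart, beyond the scatter of two such steps.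

Going by these compounds, it remains open whether a single methoxy group on a different carbon of the aromatic ring would give a number like that of compound 4. On these data alone, it is equally open whether a smaller or different group at the same place, such as a hydroxyl group, a fluorine atom or an amine, would do the same.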